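The source may hold more compounds than are shown below. What is called first, only, known or untested is meant among the compounds shown, and "the series" means these compounds.

Measured so far in a functional assay on WHCO1 cells (Homo sapiens) for antiproliferative activity, read by MTT assay, with a stated time of 48 h (a higher number here means a weaker inhibitor, a lower number a stronger inhibitor), as the read-out:
- compound 1 `C=CCSS/C=C/C[S+]([O-])CCCN1C(=O)c2ccccc2C1=O` gives 68000 nM in this test
- compound 2 `CCC[S+]([O-])C/C=C\SSC` gives 26000 nM in this test

Of these two numbers, compound 2 has the lower, which makes it the stronger inhibitor of the pair, and its gap to compound 1 lies beyond the scatter. Compound 3 `CCCSS/C=C\C[S+]([O-])CCC` has not yet been measured. Going from compound 2 to compound 3 (ethyl in place of hydrogen on a saturated chain carbon bound to a sulfur) puts ethyl in place of hydrogen on a saturated chain carbon bound to a sulfur, turning methylsulfanyl into propylsulfanyl. Going by the values given here, no two measured compounds differ in one place only, so nothing here shows directly what this change does. No shift beyond the scatter is expected: the estimated step of a 1.2-fold lower number from compound 2 to compound 3 (0.07 log units; within the scatter) is small and leans slightly toward a lower number. For compound 3 the expected value in this assay is 22000 nM with an estimated range from 10000 nM to 48000 nM around it.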

Compound 3, half-maximal inhibitory concentration: 18000 nM
Estimate against measurement, compound 3: 1.2-fold (0.09 log units) above; the range from low to high includes it.
By their numbers in this assay, from the lowest: compounds 3 and 2 (each within the scatter of the next); then compound 1.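

Compound 2 and compound 3 are the first pair shown that differ in one place only, so this position can now be read directly: in this assay, putting ethyl in place of hydrogen on a saturated chain carbon bound to a sulfur, which turns methylsulfanyl into propylsulfanyl, gives a 1.4-fold lower number from compound 2 to compound 3 (0.16 log units; within the scatter) and leaves the two compounds indistinguishable. At this place, then, the methyl and propyl ends give the same result within the normal spread of repeat measurements, and the added ethyl produces no measurable shift. Nothing available offers an explanation for this result.

Going by these compounds, whether a longer chain, an amine or a carboxylic acid at this place would shift the number beyond the scatter remains open. Compound 1 differs from both other compounds in more than one place, so it adds nothing about this position.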